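The source may report more compounds than this note shows. Statements on the series, on what has been measured and on what is new or still open speak of the compounds shown alone.

Measured so far:
compound 1, `O=C(O)c1cc(-c2cccc(COc3ccc4c(c3)CN(c3ccccc3)C4=O)c2)ccc1Cl`: 86.2%
compound 2, `CC(C)CN1Cc2cc(OCc3cccc(-c4ccc(Cl)c(C(=O)O)c4)c3)ccc2C1=O`: 63.9%

Among the compounds with values here, in an assay on HEK293 cells for positive allosteric modulation of metabotropic glutamate receptor 2 (Rattus norvegicus), read by thallium flux (a higher number here means a larger maximal response, a lower number a smaller maximal response), compound 2 stands lowest of the two numbers, the only measured step reading a number 22.3 percentage points lower from compound 1 to compound 2 (beyond the scatter). Compound 3, `CC(C)CCN1Cc2cc(OCc3cccc(-c4ccc(Cl)c(C(=O)O)c4)c3)ccc2C1=O`, differs from compound 2 by isobutyl in place of isopropyl on a saturated chain carbon bound to an amide-type nitrogen in a ring. That measured step swaps a different group and so does not bear directly on this change; nothing measured shows what lengthening the chain by one carbon does. The step is therefore expected to stay within the scatter, a number 0.9 percentage points lower from compound 2 to compound 3 (within the scatter). Compound 3 is estimated at 63%, in a range from 46% to 80%.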

Compound 3, largest response reached (Emax), in percent of the reference or control that the assay uses: 85.3%
Beside the measured number, compound 3's estimate is 22.3 percentage points below it, and the stated range ends below it.
By their numbers in this assay, from the lowest: compound 2; then compounds 3 and 1 (each within the scatter of the next).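

In this assay, a small change in the saturated chain on the amide-type nitrogen in a ring has a large effect: isopentyl in place of isobutyl gives a number 21.4 percentage points higher from compound 2 to compound 3 (beyond the scatter) and so moves the response beyond the scatter. The second step, a number 0.9 percentage points lower from compound 1 to compound 3 (within the scatter), shows that isopentyl can match phenyl here, so this response does not depend on a ring at this position. Nothing available explains why the chain change matters so much.

Still open, going by these compounds, is whether a longer chain such as hexyl would keep this response. The same is true of a chain ending in an amine or a cyclohexyl ring.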